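The source may hold more compounds than are shown below. What is called first, only, known or untested is meant among the compounds shown, and "the series" means these compounds.

Of the compounds shown here, three from this series have been tested in a functional assay on SQ20B cells (Homo sapiens) for cytotoxicity, read by MTT assay, with a stated time of 72 h; a higher number here means a weaker inhibitor, a lower number a stronger inhibitor. Compound 1 `CN(Cc1ccccc1)Cc1c(O)ccc2oc(Cc3ccccc3)cc12` gives 12000 nM. Compound 2 `CON(C)Cc1c(O)ccc2oc(Cc3ccccc3)cc12` gives 40000 nM. Compound 3 `Oc1ccc2oc(Cc3ccccc3)cc2c1CN1CCC(O)CC1` gives 13000 nM, which places it second highest of the three numbers, close to compound 1 and further from compound 2.

Two steps reach compound 3: a 1.1-fold higher number from compound 1 to compound 3 (0.03 log units; within the scatter), and a 3.1-fold lower number from compound 2 to compound 3 (0.49 log units; beyond the scatter). Exchanging the whole group on the saturated chain carbon thus moved the number little or modestly.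

Compound 4 `Oc1ccc2oc(Cc3ccccc3)cc2c1CN1CCC(N2CCCCC2)CC1` keeps that group but changes one point on it: piperidin-1-yl in place of hydroxy on a saturated ring carbon. For the measured compounds named here, no measured step changes the hydroxy of the 4-hydroxypiperidin-1-yl group, so nothing here bears directly on it; the steps into compound 3 only show that the shared core tolerates varied groups at that position without large shifts. A small step in this assay, probably within the scatter, is therefore expected for compound 4, with no firm direction. The estimate for compound 4 is 9000 nM, with a range from 3000 nM to 27000 nM. This estimate corresponds to an expected step of a 1.4-fold lower number from compound 3 to compound 4 (0.16 log units; within the scatter).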

Compound 4, half-maximal inhibitory concentration: 3000 nM
Compound 4: middle estimate off by 3.0-fold (0.48 log units), on the high side; measured number inside the range.
By their numbers in this assay, from the lowest: compound 4; then compounds 1 and 3 (each within the scatter of the next); then compound 2.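

The step in this assay is a 4.3-fold lower number from compound 3 to compound 4 (0.64 log units; beyond the scatter), so a change at this one point, on the saturated ring carbon three ring bonds from the ring nitrogen, moves the number beyond the scatter. The earlier steps shown here exchanged the whole group and did not test this point. Here, one hydroxy oxygen with its hydrogen-bond donor gives way to a six-membered ring with a nitrogen and no donor, and nothing available explains the shift.

The compounds shown leave open whether the added ring, its nitrogen or the loss of the hydroxy accounts for the step. A cyclohexyl group would keep the ring without the nitrogen, a dimethylamino group would keep the nitrogen without the ring, and a methoxy group would keep the oxygen without its hydrogen.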